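The source may hold more compounds than are shown below. What is called first, only, known or untested is meant among the compounds shown, and "the series" means these compounds.

In a functional assay on DLD-1 cells (Homo sapiens) for cytotoxicity, with a stated time of 48 h (on this read-out lower numbers stand for stronger inhibition and higher numbers for weaker inhibition), compound 1 `C[S+]([O-])/C=C/c1cc(=O)c2ccccc2o1` gives 8000 nM. Compound 2 `CCCC(=O)Oc1ccc2oc(/C=C/[S+](C)[O-])cc(=O)c2c1` gives 8700 nM, and compound 3 `Cc1ccc2oc(/C=C/[S+](C)[O-])cc(=O)c2c1` gives 7000 nM. Compound 1 therefore stands within the scatter of both others, and these three values cannot be ranked.

Compound 4 `Cc1cccc2oc(/C=C/[S+](C)[O-])cc(=O)c12` has not yet been measured. It differs from compound 1 by a single change: methyl in place of hydrogen on an aromatic carbon. This is methyl in place of hydrogen on an aromatic carbon, ortho to a fused ring and meta to a fused ring.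

The closest guide is compound 3, which carries the same kind of replacement at a different aromatic carbon: a 1.1-fold lower number from compound 1 to compound 3 (0.06 log units; within the scatter). Compound 2 shows a different replacement, (propylcarbonyl)oxy in place of hydrogen on an aromatic carbon: a 1.1-fold higher number from compound 1 to compound 2 (0.04 log units; within the scatter). The step linking these two substituted compounds is a 1.2-fold lower number from compound 2 to compound 3 (0.09 log units; within the scatter). Going by the values given here, all three steps lie within the scatter, although no measured compound has a group on the carbon that holds the methyl of compound 4. A step beyond the scatter is therefore not expected, and no clear direction can be given. The expected step is a 1.1-fold lower number from compound 1 to compound 4 (0.03 log units; within the scatter). For compound 4, the estimated value is 7500 nM, with an expected range from 3500 nM to 15000 nM.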

Compound 4, half-maximal inhibitory concentration: 5500 nM
Estimate against measurement, compound 4: 1.4-fold (0.13 log units) above, within the range that was stated.
By their numbers in this assay, from the lowest: compounds 4, 3, 1 and 2 (each within the scatter of the next).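

In this assay, going by these compounds alone, a methyl on this aromatic carbon, ortho to a fused ring and meta to a fused ring, gives a 1.5-fold lower number from compound 1 to compound 4 (0.16 log units; within the scatter) and so provides the first reading at this carbon: here a methyl leaves the number within the scatter of the unsubstituted compound. The methyl of compound 3 sits on a different aromatic carbon, and with compound 3 at 7000 nM and compound 4 at 5500 nM, these four compounds give no sign that moving the methyl between these two carbons matters in this cytotoxicity read-out. No measurement is available that could explain where the value of compound 4 falls.

Going by these compounds, a single small group on this carbon cannot show how far the position tolerates change, so it remains open whether an amine, a carboxylic acid or a longer chain such as propyl in the same place would give a step beyond the scatter. On these data alone, it is also open whether a methyl on any of the other aromatic carbons of the shared core would behave in the same way.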